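The source may report more compounds than this note shows. Statements on the series, on what has been measured and on what is new or still open speak of the compounds shown alone.

The study compares three measured compounds built on a shared core and one that has not yet been measured. Compound 1, `CC(C)CCn1cnc2c(Nc3cccc(Cl)c3)nc(N[C@H]3CC[C@H](N)CC3)nc21`, carries a (3-chlorophenyl)amino group and an isopentyl chain; in a functional assay on EOL1 cells (Homo sapiens) for inhibition, read by fluorescence, with a stated time of 72 h (on this read-out lower numbers stand for stronger inhibition of growth and higher numbers for weaker inhibition of growth), compound 1 gives 60 nM. Compound 2, `CC(C)CCn1cnc2c(Nc3ccccc3)nc(N[C@H]3CC[C@H](N)CC3)nc21`, keeps the isopentyl chain but has an anilino group in place of the (3-chlorophenyl)amino group; in this assay compound 2 gives 10 nM. Compound 3, `CCCCn1cnc2c(Nc3cccc(Cl)c3)nc(N[C@H]3CC[C@H](N)CC3)nc21`, keeps the (3-chlorophenyl)amino group of compound 1 but has a butyl chain; in this assay compound 3 gives 160 nM, the highest of the three numbers.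

Two single changes link these compounds. From compound 1 to compound 2 the change is hydrogen in place of chloro on an aromatic carbon, and it made a 6.0-fold lower number from compound 1 to compound 2 (0.78 log units; beyond the scatter). The cores of compound 1 and compound 3 differ by hydrogen in place of methyl on a saturated chain carbon bound to two saturated chain carbons, and that change made a 2.7-fold higher number from compound 1 to compound 3 (0.43 log units; beyond the scatter).

Compound 4, `CCCCn1cnc2c(Nc3ccccc3)nc(N[C@H]3CC[C@H](N)CC3)nc21`, is not yet measured. It differs from compound 3 by hydrogen in place of chloro on an aromatic carbon. The place of this change is described in the same words as the change from compound 1 to compound 2, so it is the same change, now made on the core of compound 3 rather than on the core of compound 1. Among the compounds with values here, only one earlier example of this change is available, so the range around any expectation is wide. Resting on a 6.0-fold lower number from compound 1 to compound 2 (0.78 log units; beyond the scatter), the expected step is a 5.3-fold lower number from compound 3 to compound 4 (0.73 log units; beyond the scatter). Compound 4 is accordingly estimated at 30 nM, with a likely range from 12 nM to 75 nM.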

Compound 4, concentration for 50% growth inhibition: 20 nM
Compound 4: the middle estimate sits 1.5-fold (0.18 log units) above what was measured, within the range that was stated.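

Taking chloro off the aromatic carbon of compound 3 gave an 8.0-fold lower number from compound 3 to compound 4 (0.90 log units; beyond the scatter), and in this assay this step agrees with the earlier example on the core of compound 1: the same change on two cores in this assay, a 6.0-fold lower number (0.78 log units; beyond the scatter) from compound 1 to compound 2 and an 8.0-fold lower number (0.90 log units; beyond the scatter) from compound 3 to compound 4, 1.3-fold (0.12 log units) apart, within the scatter of two such steps. The change from the isopentyl chain to the butyl chain, now on the anilino side of the set, gave a 2.0-fold higher number from compound 2 to compound 4 (0.30 log units; within the scatter), and it also agrees with its earlier example: the same change on two cores in this assay, a 2.7-fold higher number (0.43 log units; beyond the scatter) from compound 1 to compound 3 and a 2.0-fold higher number (0.30 log units; within the scatter) from compound 2 to compound 4, 1.3-fold (0.12 log units) apart, within the scatter of two such steps. Within these four compounds, then, each change kept its size when carried to the second core, but two cores and one place of substitution show only that the steps agree here, not that they would hold on other cores, and they give no reason for the agreement.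

The compounds shown leave open whether a bromo or a methoxy group in place of chloro, or a longer chain in place of the isopentyl chain, would follow the same steps. They also leave open whether the two changes would carry over in the same way in any read-out other than this assay.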